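The compounds below may be only part of what the source reports. "The series", "measured", "known", "first", "only" and "open" are said of these compounds alone.

Measured in an assay on isolated protein for displacement of a labelled ligand from metabotropic glutamate receptor 5 (Homo sapiens), with a stated time of 60 min, tested at 1 uM; a lower number here means less inhibition, a higher number more inhibition at the concentration tested (going by the name of the read-out):
compound 1 `Cc1ccc(S(=O)(=O)c2cnc3ccc(F)cc3c2N2CCC(C)CC2)cc1` gives 91%.
compound 2 `COc1ccc(S(=O)(=O)c2cnc3ccc(F)cc3c2N2CCC(C)CC2)cc1` gives 85%.
compound 3 `COCC1CCN(c2c(S(=O)(=O)c3cc(F)cc(F)c3)cnc3cc(F)ccc23)CC1` gives 83%.

On these numbers compound 2 sits within the scatter of both neighbours: its gap to compound 3 and its gap to compound 1 are each inside the usual spread, so the three cannot be separated in this assay. Going by the values given here, the only single-point step among them, a number 6 percentage points lower from compound 1 to compound 2 (within the scatter), exchanges one small substituent at the same place on the 4-substituted phenyl and stays within the scatter.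

Compound 4 `CC1CCN(c2c(S(=O)(=O)c3ccc(Cl)cc3)cnc3ccc(F)cc23)CC1` differs from compound 2 in one place: chloro in place of methoxy on an aromatic carbon. The step from compound 1 to compound 2 is the one that bears on this, since it also swaps a single group at that position; compound 3 differs from compound 2 in several places and gives no direct guidance. Given that the bearing step was within the scatter, no change beyond the scatter is expected for a number 3 percentage points higher from compound 2 to compound 4 (within the scatter), with a mild lean back toward the number of compound 1 91%.

Compound 4 is therefore estimated at 88% in this assay, with a range of 78% to 96%.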

Compound 4, a percentage reported as inhibition, at one concentration (the size of the read-out at that concentration, not a potency): 80%
Compound 4: middle estimate off by 8 percentage points, on the high side, and the stated range covers the measured number.
By their numbers in this assay, from the lowest: compounds 4, 3, 2 and 1 (each within the scatter of the next, the first and the last beyond it).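

Going by these compounds alone, with chloro in place of methyl at this position, this assay shows a number 11 percentage points lower from compound 1 to compound 4 (beyond the scatter) on the shared core, the first step that clears the usual spread, though it is only modest. The other two steps at the same place do not separate: chloro in place of methoxy gives a number 5 percentage points lower from compound 2 to compound 4 (within the scatter) and methoxy in place of methyl gives a number 6 percentage points lower from compound 1 to compound 2 (within the scatter) so compound 2 cannot be told apart from either of the other two, and only the methyl and chloro ends of this small set differ. No measurement at hand speaks to what lies behind the gap between methyl and chloro.

Still open, from the compounds shown here alone, is whether an amine or a carboxylic acid on this aromatic carbon would fall inside or outside the span set by methyl, methoxy and chloro. Also open, going by these compounds, is whether the step from methyl to chloro holds once another part of the core changes, and, as the read-out is taken at a single concentration, how these compounds compare in potency.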